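A few compounds are considered here, and "the series" means these few. Any claim that something is new, unique, unknown or untested is made for them only; others in the source may bear on it.

In a physicochemical assay for solubility, read by HPLC, in simulated intestinal fluid, with a stated time of 16 h, tested at 125 ug/mL (on this read-out lower numbers stand for lower solubility and higher numbers for higher solubility), compound 1 (`CNC(=O)c1cc(C(=O)NC2CC2)c(C)n(Cc2ccccc2)c1=O`) gives 577 ug/mL and compound 3 (`CNC(=O)c1cc(C(=O)NC2CC2)cn(Cc2cccc([C@@H](C)O)c2)c1=O`) gives 495 ug/mL, while compound 2 (`CNC(=O)c1cc(C(=O)NC2CC2)cn(Cc2cccc3[nH]ccc23)c1=O`) gives 17 ug/mL as the lowest of the three numbers. Compound 4 (`CNC(=O)c1cc(C(=O)NC2CC2)cn(Cc2cccc3c2CCN3)c1=O`) differs from compound 2 in a single group (2,3-dihydro-1H-indol-4-yl in place of 1H-indol-4-yl on a saturated chain carbon bound to an aromatic nitrogen), on a saturated chain carbon bound to an aromatic nitrogen. The five-membered ring of that group is non-aromatic in compound 4 and aromatic in compound 2. Going by the values given here, only one measured step bears on this place (a 29-fold higher number from compound 2 to compound 3 (1.46 log units; beyond the scatter)). It is large, but it brings in 3-(1-hydroxyethyl)phenyl, so no measurement covers 2,3-dihydro-1H-indol-4-yl itself. Among the compounds with values here, with that single step as the only guide, a higher number is expected in this assay, though a smaller move than the one measured, and this rests on little evidence. The estimated step is smaller than that precedent (a 3.5-fold higher number from compound 2 to compound 4 (0.55 log units; beyond the scatter)). Compound 4 is expected at an estimated 60 ug/mL (range 20 ug/mL to 250 ug/mL).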

Compound 4, solubility: 100 ug/mL
The estimate for compound 4 lay 1.7-fold (0.22 log units) below the measured number, within the range that was stated.
By their numbers in this assay, from the lowest: compound 2; then compound 4; then compounds 3 and 1 (each within the scatter of the next).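

In this assay, replacing 1H-indol-4-yl with 2,3-dihydro-1H-indol-4-yl gives (a 5.9-fold higher number from compound 2 to compound 4 (0.77 log units; beyond the scatter)), beyond the scatter. The number at this place therefore moves even when the group keeps its count of heavy atoms and its hydrogen-bond donor, and the five-membered ring changes from aromatic to non-aromatic. The new group does not reach the level set by 3-(1-hydroxyethyl)phenyl, however, with (a 5.0-fold lower number from compound 3 to compound 4 (0.69 log units; beyond the scatter)), and nothing measured here explains either step.

The compounds shown leave open whether the ring's lost aromaticity or its hydrogen-bond acceptor goes with the higher number, a question that an acetyl group on the ring nitrogen might help to address. They also leave open how an aminomethyl group or a carboxylic acid on the phenyl ring would compare with 3-(1-hydroxyethyl)phenyl.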